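The source may hold more compounds than are shown below. What is called first, only, known or untested is meant among the compounds shown, and "the series" means these compounds.

Three compounds share a common core and differ only in the group on the amide-type nitrogen in the ring. Compound 1 `COc1ccc([C@H]2CC(=O)N(Cc3cccc([N+](=O)[O-])c3)C2)cc1OC1CCCC1` carries a 3-nitrobenzyl group there; in a functional assay on HEK293 cells (Homo sapiens) for cytotoxicity (on this read-out higher numbers stand for lower toxicity in this test and lower numbers for higher toxicity in this test), compound 1 gives only a limit of > 10000 nM. Compound 2 `COc1ccc([C@H]2CC(=O)N(c3ccccc3)C2)cc1OC1CCCC1` carries a phenyl; in this assay compound 2 likewise gives only a limit of > 10000 nM. Compound 3 `COc1ccc([C@H]2CC(=O)N(c3cc(N)cc(F)c3)C2)cc1OC1CCCC1` carries a 3-amino-5-fluorophenyl; in this assay compound 3 again reaches only a limit of > 10000 nM. Compound 3 thus stands at the same limit as the two others, and the steps a step that the two limits leave unreadable from compound 1 to compound 2, a step that the two limits leave unreadable from compound 1 to compound 3 and a step that the two limits leave unreadable from compound 2 to compound 3 remain unreadable because of the limit of > 10000 nM in this assay, at which 3 of the 3 values shown sit.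

Compound 4 `COc1ccc([C@H]2CC(=O)N(c3ccncc3)C2)cc1OC1CCCC1` is not yet measured. It differs from compound 3 as follows: pyridin-4-yl in place of 3-amino-5-fluorophenyl on an amide-type nitrogen in a ring. For the measured compounds named here, none of the measured steps can be sized, so they give no direction beyond the scatter for this assay; what they do show is that three different groups on this nitrogen all left the limit in place. Compound 4 is therefore expected to give about 15000 nM in this assay, with a range from 7000 nM to 40000 nM, most probably again reported only as a limit. The expected step is a step that the limit leaves unreadable from compound 3 to compound 4.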

Compound 4, half-maximal cytotoxic concentration: > 10000 nM
Compound 4: only a limit was reported (the forecaster's own chance of this, stated with the estimate: 80%); the middle value is on the limit's open side.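

In this assay compound 4 also gives only a limit, > 10000 nM. No step from compound 1, compound 2 or compound 3 to compound 4 can be read, because every value stays a limit: the limit of > 10000 nM in this assay, at which 4 of the 4 values shown sit.

The compounds shown leave open whether any group on the amide-type nitrogen in the ring changes the result in this assay.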